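The source may report more compounds than this note shows. Statements on the series, on what has been measured and on what is new or still open speak of the compounds shown alone.

Measured so far in a functional assay on the whole organism with Scenedesmus acutus as the target, with a stated time of 20 h; a lower number here means a stronger inhibitor, a higher number a weaker inhibitor:
- compound 1 `COC(=O)c1cc(N2C(=O)C3=C(CCCC3)C2=O)c(F)cc1Cl`: 170 nM
- compound 2 `CCOC(=O)c1cc(N2C(=O)C3=C(CCCC3)C2=O)c(F)cc1Cl`: 87.1 nM
- compound 3 `CCOC(=O)c1cc(N2C(=O)C3=C(CCCC3)C2=O)ccc1Cl`: 2140 nM

Of these three, compound 3 has the highest number, 2140 nM, which makes it the weakest inhibitor of the set in this assay. Compound 4 `CCCCCCCCOC(=O)c1cc(N2C(=O)C3=C(CCCC3)C2=O)ccc1Cl` differs from it by hexyl in place of hydrogen on a saturated chain carbon, two bonds along the chain from an oxygen next to a carbonyl group. Cut one bond further out, the same change reads ethyl to octyl.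

Among the compounds with values here, only one measured step concerns this chain: a 2.0-fold lower number from compound 1 to compound 2 (0.29 log units; within the scatter). It is a much shorter extension, and it was measured on compounds that carry the fluoro group absent from compound 3. The other step, a 25-fold higher number from compound 2 to compound 3 (1.39 log units; beyond the scatter), is large, but it sits on an aromatic carbon and says nothing about chain length. Within the data shown here, it shows only that compound 3 starts from a weaker level. No chain longer than ethyl has been measured, so the direction of a change this large is open. With no measured basis for a shift either way, the central expectation is no change beyond the scatter, with wide uncertainty. The expected outcome is a 1.2-fold higher number from compound 3 to compound 4 (0.07 log units; within the scatter). For compound 4 the estimated value is 2500 nM, with an expected range from 500 nM to 12000 nM.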

Compound 4, half-maximal inhibitory concentration: > 100000 nM
Compound 4: only a limit was reported; the forecaster's own chance of this, stated with the estimate: 10%; middle value at least 40-fold (1.60 log units) from the limit.
By their numbers in this assay, from the lowest: compounds 2 and 1 (each within the scatter of the next); then compound 3. At a limit, above all of these: compound 4.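

In this assay compound 4 stands at > 100000 nM, which is a limit of the assay and not a number. Taking the chain from ethyl to octyl, with hexyl in place of hydrogen on a saturated chain carbon, gives an at least 46-fold higher number from compound 3 to compound 4 (1.66 log units; beyond the scatter), the first step along this chain that lies beyond the scatter, whereas the shorter extension, a 2.0-fold lower number from compound 1 to compound 2 (0.29 log units; within the scatter), does not, and that shorter step was read on compounds carrying the fluoro group. Chain length at this position can therefore shift the number strongly in the weaker direction, and the step has no fixed upper size, only a lower bound set by the limit: the limit of > 100000 nM in this assay, at which 1 of the 4 values shown sits.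

The compounds shown leave open where between ethyl and octyl the loss sets in, a question that a butyl chain on the core of compound 3 would help settle. They also leave open whether an octyl chain costs as much on the fluoro-bearing core of compound 2, and whether a chain ending in an amine or a carboxylic acid behaves as octyl does.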